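Trading a Triple Bond for a Double Bond in a Polyyne Acid

This account rests on a few compounds, and the source may have more. Where it says the series, first, only, none or still open, it means among the compounds named here.

Measured so far:
Compound 1, `O=C(O)CCCCCCCC#CC#CC#CC#C[C@@H](O)CO`, gives 10.1 ug/mL in a functional assay on M109 cells (Mus musculus) for cytotoxicity; a higher number here means that more compound is needed for the effect, a lower number that less compound is needed.
Compound 2, `C[C@H](O)C#CC#CC#CC#CCCCCCCCC(=O)O`, gives 3.7 ug/mL in this assay.

Compound 2 has the lowest number of the two, so less of it is needed for the effect than of compound 1, and the gap lies beyond the scatter: a 2.7-fold lower number from compound 1 to compound 2 (0.44 log units; beyond the scatter). Compound 3, `C[C@H](O)/C=C/C#CC#CC#CCCCCCCCC(=O)O`, has not yet been measured. It differs from compound 2 in one place: 3-hydroxybut-1-en-1-yl in place of 3-hydroxybut-1-yn-1-yl on a triple-bonded carbon. Within the data shown here, the single measured step concerns a hydroxy group being removed from a chain carbon, not a triple bond being turned into a double bond, so it does not bear on this change, and nothing among the measured compounds shows what such a change does here. The expectation is therefore no step beyond the scatter, and compound 3 is expected to give 4 ug/mL, with a range from 1.5 ug/mL to 11 ug/mL, which corresponds to a 1.1-fold higher number from compound 2 to compound 3 (0.03 log units; within the scatter).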

Compound 3, concentration for half-maximal effect: 5.4 ug/mL
Compound 3: the middle estimate sits 1.4-fold (0.13 log units) below what was measured, and the stated range covers the measured number.
By their numbers in this assay, from the lowest: compounds 2, 3 and 1 (each within the scatter of the next, the first and the last beyond it).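

In this assay, replacing 3-hydroxybut-1-yn-1-yl with 3-hydroxybut-1-en-1-yl on this triple-bonded carbon gives a step within the scatter (a 1.5-fold higher number from compound 2 to compound 3 (0.16 log units; within the scatter)), so this measurement does not separate the triple bond from the double bond at this position. Replacing 3,4-dihydroxybut-1-yn-1-yl with 3-hydroxybut-1-en-1-yl also stays within the scatter (a 1.9-fold lower number from compound 1 to compound 3 (0.27 log units; within the scatter)), although this swap changes both the bond and the hydroxy count. No supporting measurement is available to explain either result.

The compounds shown leave open whether a fully saturated 3-hydroxybutyl group at this place would also stay within the scatter of compound 2. They also do not show what an amine in place of the hydroxy group of 3-hydroxybut-1-en-1-yl would do.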